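The compounds below may be only part of what the source reports. "The series", "measured", "known", "first", "only" and "open" are said of these compounds alone.

Of the compounds shown here, three have so far been measured in an ADME assay on HEp-2 cells (Homo sapiens) for cytotoxicity; on this read-out higher numbers stand for lower toxicity in this test and lower numbers for higher toxicity in this test. Compound 1 `Cc1ccc(NC(=O)CNS(=O)(=O)c2cccc3cccnc23)c(C)c1` reports only a limit in this assay, > 50000 nM, and that limit is the limit of > 50000 nM in this assay, at which 1 of the 3 values shown sits. Compound 2 `Cc1cccc(NC(=O)[C@@H]2CCCN2S(=O)(=O)c2cccc3cccnc23)c1` gives 25500 nM in this assay and stands at the lower of the two numbers, though within the scatter of compound 3 `Cc1ccc(NC(=O)[C@@H]2CCCN2S(=O)(=O)c2cccc3cccnc23)cc1`, which gives 31700 nM in this assay. Going by the values given here, the only step between measured compounds, a 1.2-fold higher number from compound 2 to compound 3 (0.09 log units; within the scatter), also concerns the group on the amide-type nitrogen. Compound 4 `CCc1ccccc1NC(=O)[C@@H]1CCCN1S(=O)(=O)c1cccc2cccnc12` has not yet been measured; it differs from compound 2 by 2-ethylphenyl in place of 3-methylphenyl on an amide-type nitrogen. Among the compounds with values here, because a 1.2-fold higher number from compound 2 to compound 3 (0.09 log units; within the scatter) is the one comparable step, no shift beyond the scatter is expected for compound 4 in this assay. Compound 4 is estimated at 28000 nM in this assay, within 12000 nM to 60000 nM. The expected step is a 1.1-fold higher number from compound 2 to compound 4 (0.04 log units; within the scatter).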

Compound 4, half-maximal cytotoxic concentration: > 50000 nM
Compound 4 was reported as a limit; the forecaster's own chance of this, stated with the estimate: 25%; middle value at least 1.7-fold (0.25 log units) away from the limit.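

In this assay compound 4, with 2-ethylphenyl on the amide-type nitrogen, is reported only as a limit, so its true number is not known. The change gives an at least 1.9-fold higher number from compound 2 to compound 4 (0.29 log units; that floor lies within the scatter) and an at least 1.5-fold higher number from compound 3 to compound 4 (0.19 log units; that floor lies within the scatter), so these floors alone do not establish a shift beyond the scatter. Compound 4 thus joins the compounds reported only as a limit: the limit of > 50000 nM in this assay, at which 2 of the 4 values shown sit.

The compounds shown leave open whether the ethyl chain or its place on the phenyl ring accounts for this reading. As far as these compounds go, how 2-methylphenyl, or a phenyl ring carrying an amine or a carboxylic acid, would read in this assay also remains open.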